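The source may hold more compounds than are shown below. What is called first, only, known or untested is meant among the compounds shown, and "the series" means these compounds.

Values in a physicochemical assay for solubility, using the shake flask method, with a stated time of 12 h; on this read-out lower numbers stand for lower solubility and higher numbers for higher solubility:
- compound 1 `O=C(/C=C/c1ccc(O)c(O)c1)CC(=O)/C=C/c1cccc(O)c1O`: 3800 nM
- compound 2 `O=C(/C=C/c1ccc(O)cc1)CC(=O)/C=C/c1cccc(O)c1O`: 4800 nM
- compound 3 `O=C(/C=C/c1ccccc1O)/C=C/c1cccc(O)c1O`: 151000 nM

Compound 3 has the highest number of the three, and its gap to each of the other two lies well beyond the scatter. Compound 4 `O=C(/C=C/c1cccc(O)c1)/C=C/c1cccc(O)c1O` has not yet been measured. It differs from compound 3 by one change: 3-hydroxyphenyl in place of 2-hydroxyphenyl on a double-bonded chain carbon bound to a double-bonded chain carbon. The two compounds have the same atoms, joined differently.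

For the measured compounds named here, only one measured step offers any guide, and that is a 1.3-fold higher number from compound 1 to compound 2 (0.10 log units; within the scatter). It puts hydrogen in place of hydroxy on an aromatic carbon, so it removes a group rather than exchanging one for another. It also comes from compounds whose chain differs from that of compound 3, so it bears only loosely on this change. Going by the values given here, no measured pair shows this exact exchange.

With so little evidence, no shift beyond the scatter is expected, although a small drop seems slightly more likely than a rise. The expected change is a 1.4-fold lower number from compound 3 to compound 4 (0.14 log units; within the scatter). Compound 4 is estimated at 110000 nM, with an expected range from 30000 nM to 250000 nM.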

Compound 4, solubility: 184000 nM
The estimate for compound 4 lay 1.7-fold (0.22 log units) below the measured number; the range from low to high includes it.
By their numbers in this assay, from the lowest: compounds 1 and 2 (each within the scatter of the next); then compounds 3 and 4 (each within the scatter of the next).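

In this assay, 3-hydroxyphenyl in place of 2-hydroxyphenyl on a double-bonded chain carbon bound to a double-bonded chain carbon gives a 1.2-fold higher number from compound 3 to compound 4 (0.09 log units; within the scatter), so this pair of compounds cannot be told apart on this read-out. For the compounds shown here, this is the first measured case of one group being exchanged for another at this place, whereas the only earlier step removed a group and came from compounds with a different chain. At this place, on this core, changing 2-hydroxyphenyl to 3-hydroxyphenyl leaves the number within the usual scatter of repeated measurements, and no measurement shown gives a reason for this result.

The compounds shown leave open whether other groups at this place, such as 4-hydroxyphenyl, unsubstituted phenyl, or a phenyl ring carrying methoxy, an amine or a carboxylic acid instead of hydroxy, would also stay within the scatter of compound 3. They also leave open whether the same exchange would give a similarly small step on the longer chain of compound 1 and compound 2.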